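Fluoro for methoxy on the aryl of the triazole

A few compounds are considered here, and "the series" means these few. Any claim that something is new, unique, unknown or untested is made for them only; others in the source may bear on it.

The measured compounds in this set are:
compound 1, `COc1ccc(/C=C\C(=O)O)c(OCc2cn(-c3ccc(NC(C)=O)cc3)nn2)c1CC=C(C)C`, with 17400 nM
compound 3, `COc1ccc(/C=C\C(=O)O)c(OCc2cn(-c3ccc(NC(=O)c4ccccc4)cc3)nn2)c1CC=C(C)C`, with 23300 nM
compound 2, `COc1ccccc1-n1cc(COc2c(/C=C\C(=O)O)ccc(OC)c2CC=C(C)C)nn1`, with "not determined" (no result reported)

In a functional assay on T47D cells (Homo sapiens) for cytotoxicity, read by MTT assay, with a stated time of 24 h (on this read-out lower numbers stand for stronger inhibition and higher numbers for weaker inhibition), compound 1 gives 17400 nM, and compound 3 gives 23300 nM. Among the compounds with values here, the only step between measured compounds, a 1.3-fold higher number from compound 1 to compound 3 (0.13 log units; within the scatter), shows that swapping the group on the carbonyl carbon leaves the read-out essentially where it was. Compound 2 has no number in this assay, so it cannot be placed on the scale at all; it shares its core with compounds 1 and 3 and differs from them only in the group carried on the aryl ring of the triazole.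

Compound 4, `COc1ccc(/C=C\C(=O)O)c(OCc2cn(-c3ccccc3F)nn2)c1CC=C(C)C`, differs from compound 2 by fluoro in place of methoxy on an aromatic carbon, ortho to a large group. Within the data shown here, no measured step bears on this change, since the single step in hand alters a different part of the molecule and lies within the scatter. On that basis no step beyond the scatter is expected in this assay, and compound 4 is expected to land close to compounds 1 and 3. Compound 4 is estimated at 20000 nM, with an expected range from 6000 nM to 70000 nM.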

Compound 4, half-maximal inhibitory concentration: 11000 nM
The estimate for compound 4 lay 1.8-fold (0.26 log units) above the measured number, within the range that was stated.
By their numbers in this assay, from the lowest: compounds 4, 1 and 3 (each within the scatter of the next, the first and the last beyond it).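

In this assay, within the data shown here, the step of a 1.6-fold lower number from compound 1 to compound 4 (0.20 log units; within the scatter) is the first to change the whole aryl group on the aromatic nitrogen, not only the far end of its amide, and the number stays within the scatter even though 2-fluorophenyl carries no amide at all. Together with the step of a 1.3-fold higher number from compound 1 to compound 3 (0.13 log units; within the scatter), it shows that three different aryl groups at this position, in compounds 1, 3 and 4, give numbers that sit close together, with no step between a listed pair reaching beyond the scatter. The swap of fluoro for methoxy itself cannot be read, as compound 2 has no number to set against compound 4, and nothing measured alongside these values speaks to what lies behind them.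

The compounds shown leave open whether an unsubstituted phenyl, or an amine or a hydroxyl in place of the fluoro, would keep the number in the same range. They also leave open whether this flat response holds when the rest of the molecule changes, for instance with a methyl ester in place of the carboxylic acid of the shared core.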